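Cytotoxicity notes: from compound 1 to compound 4

The compounds below may be only part of what the source reports. "The series", "measured", "known", "first", "only" and "open" are said of these compounds alone.

Compound 1 `O=C(COc1cccc2ccccc12)N/N=C/c1cccc(O)c1` in an ADME assay on HEL cells (Homo sapiens) for cytotoxicity (on this read-out higher numbers stand for lower toxicity in this test and lower numbers for higher toxicity in this test), gives 100 ug/mL, level with compound 2 at the digits shown. Compound 2 `COc1ccc(/C=N/NC(=O)COc2cccc3ccccc23)cc1O` gives 100 ug/mL in this assay, so the step of no change at the digits printed from compound 1 to compound 2 (within the scatter) is a flat one. Compound 3 `O=C(COc1cccc2ccccc12)N/N=C/c1cccc([N+](=O)[O-])c1` is known only through a limit of the assay: in this assay compound 3 gives >= 20 ug/mL, which is a limit and not a number. On that point, (the limit of >= 20 ug/mL in this assay, at which 1 of the 3 values shown sits); the step that the limit leaves unreadable from compound 1 to compound 3 therefore cannot be sized.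

Compound 4 `O=C(COc1cccc2ccccc12)N/N=C/c1ccccc1Cl` differs from compound 1 in one place: 2-chlorophenyl in place of 3-hydroxyphenyl on a carbon with a double bond to nitrogen. Neither measured step touches this change directly: the methoxy step was flat, and the nitro step is unreadable. Nothing in the measured steps points to a shift beyond the scatter, so the expectation for compound 4 in this assay is a value close to compound 1, with room for a modest move toward higher toxicity that the data neither support nor rule out. Compound 4 is expected at 100 ug/mL, within 20 ug/mL to 100 ug/mL. The step of no change at the digits printed from compound 1 to compound 4 (within the scatter) is expected to stay within the scatter.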

Compound 4, minimum cytotoxic concentration: 100 ug/mL
Compound 4: the middle estimate sits on the measured number at the digits printed; the range from low to high includes it.
By their numbers in this assay, from the lowest: compounds 1, 2 and 4 (each within the scatter of the next).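

Replacing 3-hydroxyphenyl with 2-chlorophenyl on a carbon with a double bond to nitrogen gives no change at the digits printed from compound 1 to compound 4 (within the scatter) in this assay. For the compounds shown here, this is the first readable step that removes the hydroxy group, and with it the hydrogen-bond donor and acceptor counted for 3-hydroxyphenyl. For this one replacement, then, the read-out does not depend on keeping that hydroxy group, and the aromatic ring at this place tolerates a chlorine in its stead.

Compound 3 is known only through a limit, so its step from compound 1 cannot be read: the limit of >= 20 ug/mL in this assay, at which 1 of the 4 values shown sits.

On these data alone, it also remains open whether an amine or a carboxylic acid on this ring, or a longer chain in place of the ring, would shift the read-out beyond the scatter.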